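Swapping the amide aryl group: chloropyridyl to cyanophenyl

The source may report more compounds than this note shows. Statements on the series, on what has been measured and on what is new or still open speak of the compounds shown alone.

Measured so far, in a functional assay on HeLa cells (Homo sapiens) for antiproliferative activity, read by CCK-8 assay, with a stated time of 72 h; on this read-out lower numbers stand for stronger inhibition and higher numbers for weaker inhibition:
- compound 1, `O=C(Nc1cccc(-c2oc3cc(-c4ccc(F)cc4)ccc3c(=O)c2O)c1)c1ccccc1F`, gives 5630 nM
- compound 2, `O=C(Nc1cccc(-c2oc3cc(-c4ccc(F)cc4)ccc3c(=O)c2O)c1)c1ccc(C(F)(F)F)cc1`, gives 17400 nM
- compound 3, `O=C(Nc1cccc(-c2oc3cc(-c4ccc(F)cc4)ccc3c(=O)c2O)c1)c1ccc(Cl)nc1`, gives 4080 nM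

Compound 3 shows the lowest of the three numbers; the step of a 1.4-fold lower number from compound 1 to compound 3 (0.14 log units; within the scatter) stays within the scatter, while the step of a 4.3-fold lower number from compound 2 to compound 3 (0.63 log units; beyond the scatter) lies beyond it. Compound 4, `N#Cc1ccc(C(=O)Nc2cccc(-c3oc4cc(-c5ccc(F)cc5)ccc4c(=O)c3O)c2)cc1`, is not yet measured. Its change from compound 3 is 4-cyanophenyl in place of 6-chloropyridin-3-yl on a carbonyl carbon. Both steps touch the same place, and the only one beyond the scatter, a 4.3-fold lower number from compound 2 to compound 3 (0.63 log units; beyond the scatter), ran against a phenyl carrying a further group, as the entering group does. A modest rise in the number is therefore expected for compound 4, shown as a 1.7-fold higher number from compound 3 to compound 4 (0.23 log units; within the scatter). Compound 4 is estimated at 7000 nM, in the range 2500 nM to 20000 nM.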

Compound 4, half-maximal inhibitory concentration: 23300 nM
Compound 4: middle estimate off by 3.3-fold (0.52 log units), on the low side; the measured number lies above the stated range.
By their numbers in this assay, from the lowest: compounds 3 and 1 (each within the scatter of the next); then compounds 2 and 4 (each within the scatter of the next).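

In this assay the swap from 6-chloropyridin-3-yl gives a 5.7-fold higher number from compound 3 to compound 4 (0.76 log units; beyond the scatter) and the swap from 2-fluorophenyl gives a 4.1-fold higher number from compound 1 to compound 4 (0.62 log units; beyond the scatter) while cyano in place of trifluoromethyl gives a 1.3-fold higher number from compound 2 to compound 4 (0.13 log units; within the scatter) and so makes no clear difference. Within the data shown here, at this position, 4-cyanophenyl and 4-(trifluoromethyl)phenyl now fall together on the weaker side of this small set, whereas the earlier compounds offered only one such phenyl. No measurement shown explains this result. Still open, from the compounds shown here alone, is whether an amine or a methoxy group on the same phenyl would also give a high number. An unsubstituted phenyl would show whether the 4-position group matters at all.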